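Swapping benzyl for trimethylphenyl on a shared core

The compounds below may be only part of what the source reports. "The series", "measured", "known", "first", "only" and "open" are said of these compounds alone.

Measured so far:
compound 1, `Cc1ccccc1Nc1nc(Nc2cccnc2)ncc1Cl`: 22900 nM
compound 2, `CN1CCN(c2ccc(Nc3ncc(Cl)c(NCc4ccccc4)n3)nc2)CC1`: 20300 nM

Both compounds were tested in an ADME assay on L02 cells (Homo sapiens) for inhibition, read by CCK-8 assay, with a stated time of 48 h; on this read-out lower numbers stand for stronger inhibition of growth and higher numbers for weaker inhibition of growth. Compound 1 gives 22900 nM, and compound 2 gives 20300 nM. Compound 2 has the lowest of the two numbers, but its gap to compound 1 lies within the scatter, so the two cannot be told apart on these data.

Compound 3, `Cc1cc(C)c(Nc2nc(Nc3ccc(N4CCN(C)CC4)cn3)ncc2Cl)c(C)c1`, has not yet been measured. It differs from compound 2 in one place: 2,4,6-trimethylphenyl in place of benzyl on a nitrogen on an aromatic ring. Among the measured compounds shown here, no step between two measured compounds matches this change, so any expectation rests only on the two numbers already seen, which sit close together. Compound 3 is therefore expected to give 18000 nM in this assay, with a range from 6000 nM to 50000 nM. The expected step is a 1.1-fold lower number from compound 2 to compound 3 (0.05 log units; within the scatter), not beyond the scatter in either direction.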

Compound 3, concentration for 50% growth inhibition: 20500 nM
Compound 3: the middle estimate sits 1.1-fold (0.06 log units) below what was measured; the range from low to high includes it.
By their numbers in this assay, from the lowest: compounds 2, 3 and 1 (each within the scatter of the next).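

In this assay, putting 2,4,6-trimethylphenyl in place of benzyl on a nitrogen on an aromatic ring gives a 1.0-fold higher number from compound 2 to compound 3 (0.00 log units; within the scatter) and so leaves the reading unchanged within the scatter. Among the compounds shown here, this is the first direct one-place comparison at this position, and it shows that these two carbon-only aromatic groups cannot be told apart on this read-out, even though one is joined through an extra carbon and the other carries three methyl groups. The data shown offer no measured explanation for this flat result.

On these data alone, it remains open whether a different kind of group on this nitrogen, such as a cyclohexyl ring, a longer alkyl chain or a chain ending in a carboxylic acid, would move the number beyond the scatter. One step also cannot show whether the same swap would behave alike on a different core.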